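The compounds below may be only part of what the source reports. "The series", "measured", "known", "first", "only" and "open" are said of these compounds alone.

Measured compounds:
Compound 1 `CCCCCCCCOC(=O)C(O)Cn1cnc2c(N)ncnc21` – in a functional assay on Vero cells (Chlorocebus sabaeus) for cytotoxicity (a higher number here means that more compound is tolerated, a lower number that less compound is tolerated), compound 1 gives 200 ug/mL.
Compound 2 `CC(C)OC(=O)C(O)Cn1cnc2c(N)ncnc21` – in this assay compound 2 gives > 400 ug/mL, which is a limit of the assay rather than a number.

Among the measured compounds shown here, compound 1 holds the only true number here; the other result is a limit (the limit of > 400 ug/mL in this assay, at which 1 of the 2 values shown sits). Compound 3 `Nc1ncnc2c1ncn2CC(O)C(=O)OC1CCCCC1` differs from compound 1 by cyclohexyl in place of octyl on an oxygen next to a carbonyl group. For the measured compounds named here, the one measured step that bears on this, an at least 2.0-fold higher number from compound 1 to compound 2 (0.30 log units; that floor lies within the scatter), also replaced octyl on that oxygen and gave a higher number, though its floor sits within the scatter. For compound 3 a rise of similar kind is expected, a 2.0-fold higher number from compound 1 to compound 3 (0.30 log units; within the scatter). Compound 3 is therefore estimated at 400 ug/mL, with a range from 200 ug/mL to 800 ug/mL.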

Compound 3, minimum cytotoxic concentration: 100 ug/mL
Compound 3: the middle estimate sits 4.0-fold (0.60 log units) above what was measured; measured number below the stated range.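

On an oxygen next to a carbonyl group, cyclohexyl in place of octyl gives a 2.0-fold lower number from compound 1 to compound 3 (0.30 log units; within the scatter) and so does not set the ring apart from the chain in this assay. Cyclohexyl in place of isopropyl gives an at least 4.0-fold lower number from compound 2 to compound 3 (0.60 log units; beyond the scatter), which shows that the groups on this oxygen can differ beyond the scatter. That step starts from a limit for compound 2 and not from a number: the limit of > 400 ug/mL in this assay, at which 1 of the 3 values shown sits.

As far as these compounds go, how an ethyl or a benzyl group on this oxygen, or a free carboxylic acid, would compare remains open. From the compounds shown here alone, the full size of the gap between compound 2 and compound 3 also remains open.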